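The source may hold more compounds than are shown below. What is called first, only, known or untested is meant among the compounds shown, and "the series" means these compounds.

Measured in a functional assay on HT-29 cells (Homo sapiens) for cytotoxicity, read by XTT assay, with a stated time of 72 h; a higher number here means a weaker inhibitor, a lower number a stronger inhibitor:
- Compound 1 `CCCCCCCCCCCCCCCCCCc1c(O)cc(O)c(C(C)=O)c1O`: 28000 nM
- Compound 2 `CC(C)=CCC/C=C(\C)Cc1c(O)cc(O)c2c(=O)cc(-c3ccccc3)oc12`: 32000 nM
- Compound 3 `CCCCCCCCCCCCCCCCCCOc1cc(O)c(C(C)=O)c(O)c1`: > 100000 nM, a limit rather than a number

Compound 2 gives 32000 nM and compound 1 gives 28000 nM, so these two lie within the usual scatter of each other. Compound 4 `CC(C)=CCC/C=C(\C)Cc1c(OC/C=C(\C)CCC=C(C)C)cc(O)c2c(=O)cc(-c3ccccc3)oc12` is compound 2 with 3,7-dimethylocta-2,6-dien-1-yl in place of hydrogen on an oxygen on an aromatic ring. Compound 3 also carries a long chain on such an oxygen, and its result is a limit, > 100000 nM. A modest move towards a weaker inhibitor is therefore expected in this assay, estimated as a 1.6-fold higher number from compound 2 to compound 4 (0.19 log units; within the scatter). For compound 4 the estimated value is 50000 nM, with an expected range of 18000 nM to 100000 nM.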

Compound 4, half-maximal inhibitory concentration: > 100000 nM
Compound 4 ended at the assay's limit (the forecaster's own chance of this, stated with the estimate: 30%); middle value at least 2.0-fold (0.30 log units) from the limit.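

In this assay, going by these compounds alone, replacing hydroxy with (3,7-dimethylocta-2,6-dien-1-yl)oxy gives an at least 3.1-fold higher number from compound 2 to compound 4 (0.49 log units; beyond the scatter), the first change at a single place that can be read here. It shows that this oxygen does not tolerate the added chain without a loss in this assay. The result for compound 4 is a limit, not a number, and compound 3, which also carries a long chain on such an oxygen, sits at it too: the limit of > 100000 nM in this assay, at which 2 of the 4 values shown sit.

From the compounds shown here alone, how far the loss truly goes stays open. So does whether a methyl or a short chain ending in an amine on this oxygen would keep the value of compound 2.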